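The source may hold more compounds than are shown below. What is called first, only, known or untested is meant among the compounds shown, and "the series" means these compounds.

Three compounds share one core and differ only in the group attached to the saturated chain carbon bound to the carbonyl carbon. Compound 1 `CC(C)C[C@H](N)c1cc(C(F)(F)F)ccc1N1CCN(C(=O)COc2ccc(O)cc2)CC1` gives 4600 nM in an assay on HEK293 cells for displacement of a labelled ligand from Melanocortin receptor 4 (Homo sapiens); on this read-out higher numbers stand for weaker inhibition and lower numbers for stronger inhibition. Compound 2 `CC(C)C[C@H](N)c1cc(C(F)(F)F)ccc1N1CCN(C(=O)CNc2ccccc2)CC1` gives 3600 nM in this assay, and compound 3 `CC(C)C[C@H](N)c1cc(C(F)(F)F)ccc1N1CCN(C(=O)COc2cccc(Cl)c2Cl)CC1` gives 2500 nM. On these numbers compound 2 sits between the other two: there is a 1.3-fold lower number from compound 1 to compound 2 (0.11 log units; within the scatter) and a 1.4-fold lower number from compound 2 to compound 3 (0.16 log units; within the scatter), and the gap a 1.8-fold lower number from compound 1 to compound 3 (0.26 log units; within the scatter) is likewise within the scatter, so the three values cannot be told apart.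

Compound 4 `CC(C)C[C@H](N)c1cc(C(F)(F)F)ccc1N1CCN(C(=O)COc2ccc3ccccc3c2)CC1` has not yet been measured. It differs from compound 2 in one place: (naphthalen-2-yl)oxy in place of anilino on a saturated chain carbon bound to a carbonyl carbon. Going by the values given here, the closest precedent is the step from compound 2 to compound 3, where anilino also gave way to an aryl group on oxygen with a change within the scatter; the exchange of one aryl group for another on the oxygen, from compound 1 to compound 3, was also within the scatter. On this basis the expected step of a 1.4-fold lower number from compound 2 to compound 4 (0.16 log units; within the scatter) is none beyond the scatter, and compound 4 is estimated at 2500 nM, within a range of 900 nM to 7000 nM.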

Compound 4, inhibition constant: 2000 nM
Compound 4: middle estimate off by 1.3-fold (0.10 log units), on the high side; measured number inside the range.
By their numbers in this assay, from the lowest: compounds 4, 3, 2 and 1 (each within the scatter of the next, the first and the last beyond it).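

Replacing anilino with the larger (naphthalen-2-yl)oxy, with 11 heavy atoms in place of 7 and two aromatic rings in place of one, gives a 1.8-fold lower number from compound 2 to compound 4 (0.26 log units; within the scatter) and so does not separate the two compounds. Swapping 2,3-dichlorophenyl for naphthalen-2-yl on the oxygen gives a 1.3-fold lower number from compound 3 to compound 4 (0.10 log units; within the scatter) and likewise separates nothing. The step from 4-hydroxyphenyl to naphthalen-2-yl is different, with a 2.3-fold lower number from compound 1 to compound 4 (0.36 log units; beyond the scatter) as the first gap in this set that can be told apart, though it is modest and no data shown here explain it.

All the groups shown at this position reach an aromatic ring through an oxygen or a nitrogen. From the compounds shown here alone, what a carboxylic acid, a primary amine or a cyclohexyl ring would do here remains open, as does the effect of a longer chain before the aromatic ring.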